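The source may report more compounds than this note shows. Statements on the series, on what has been measured and on what is new or still open speak of the compounds shown alone.

Compound 1 `Cc1ccc(C(=O)N/N=C/c2cc(I)c(O)c(I)c2)cc1` and compound 2 `COc1ccc(C(=O)N/N=C/c2cc(I)c(O)c(I)c2)cc1` share one core; compound 3 `Cc1ccc(C(=O)NNC(=O)c2cc(I)cc(I)c2O)cc1` is built on a second core, and the difference between the two cores is not broken down here. In a functional assay on HepG2 cells (Homo sapiens) for cytotoxicity, with a stated time of 24 h (on this read-out lower numbers stand for stronger inhibition and higher numbers for weaker inhibition), compound 1 reaches only a limit of the assay, > 100000 nM. Compound 2 likewise reaches only a limit of the assay in this assay, > 100000 nM. The step that the two limits leave unreadable from compound 1 to compound 2 is therefore unreadable; the change behind it is methoxy in place of methyl on an aromatic carbon. Going by the values given here, compound 3 gives 86400 nM in this assay, the only number in the set, the other two values sitting at the limit of > 100000 nM in this assay, at which 2 of the 3 values shown sit. Compound 4 `COc1ccc(C(=O)NNC(=O)c2cc(I)cc(I)c2O)cc1` is not yet measured; it differs from compound 3 by methoxy in place of methyl on an aromatic carbon, the same change, at the same place, as that from compound 1 to compound 2. The expected step of a 1.2-fold higher number from compound 3 to compound 4 (0.06 log units; within the scatter) rests on compound 3 giving 86400 nM and on the earlier step of the same change being unreadable. Compound 4 is thus estimated at 100000 nM, expected to fall between 40000 nM and 250000 nM, with a real chance that only a limit is reported.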

Compound 4, half-maximal inhibitory concentration: 132000 nM
The estimate for compound 4 lay 1.3-fold (0.12 log units) below the measured number, within the range that was stated.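

In this assay, methoxy in place of methyl on an aromatic carbon of the second core gives a 1.5-fold higher number from compound 3 to compound 4 (0.18 log units; within the scatter), so this change leaves no readable mark on that core. On the first core the same change cannot be read, as both of its compounds sit at a limit of the assay: the limit of > 100000 nM in this assay, at which 2 of the 4 values shown sit. Whether the change carries from one core to the other is therefore not shown, and neither agreement nor disagreement between the cores can be claimed, since one readable step within the scatter has nothing to be set against.

The compounds shown leave open whether any other group at this place, para to a large group, would move the number beyond the scatter on either core, an amine, a carboxylic acid or a longer chain such as butoxy being examples. Also open, from the compounds shown here alone, is whether the first core can give a number rather than a limit, which a direct comparison between the cores would need.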